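Methyl on an Aromatic Oxygen in Cytotoxicity-Inert Compounds

The compounds below may be only part of what the source reports. "The series", "measured", "known", "first", "only" and "open" are said of these compounds alone.

Compounds 1, 2 and 3 share a common core and differ only in the groups carried on a pendant aromatic ring. Compound 1 is `Oc1cccc(CNc2ncnc3c2ncn3C2CCCCO2)c1`. Compound 2 is `COc1cccc(CNc2ncnc3c2ncn3C2CCCCO2)c1`. Compound 3 is `COc1cc(CNc2ncnc3c2ncn3C2CCCCO2)ccc1O`. All three were tested in an ADME assay on BJ cells (Homo sapiens) for cytotoxicity, read by MTT assay, with a stated time of 72 h (a higher number here means a weaker inhibitor, a lower number a stronger inhibitor), a cell-based test of how strongly a compound harms cells rather than of any specific target.

In this assay compound 1 gives > 100000 nM, which is a limit of the assay and not a number. In this assay compound 2 gives > 100000 nM, again a limit rather than a number. In this assay compound 3 gives > 100000 nM, also only a limit. The change methyl in place of hydrogen on an oxygen on an aromatic ring therefore produces a step that the two limits leave unreadable from compound 1 to compound 2, and the step that the two limits leave unreadable from compound 2 to compound 3 is likewise unreadable, because of the limit of > 100000 nM in this assay, at which 3 of the 3 values shown sit.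

Compound 4, still unmeasured, is `COc1ccc(CNc2ncnc3c2ncn3C2CCCCO2)cc1OC`. Its difference from compound 3 is methyl in place of hydrogen on an oxygen on an aromatic ring; this is the same change as that from compound 1 to compound 2, made at a place described in exactly the same words. How the core of compound 3 differs from that of compound 1 is not broken down here.

Since all three measured compounds sit at the limit, compound 4 is expected to sit there too, with a step of a number no higher from compound 3 to compound 4 (the limit leaves the size open) that is essentially flat. Compound 4 is accordingly estimated at 100000 nM, expected to lie between 50000 nM and 300000 nM.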

Compound 4, half-maximal inhibitory concentration: > 100000 nM
Compound 4 was reported as a limit (the forecaster's own chance of this, stated with the estimate: 90%); the middle value lies on the limit itself.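

Compound 4 is also reported only as a limit of the assay and not as a number, so neither the step to it from compound 2 nor the step to it from compound 3 can be read: the limit of > 100000 nM in this assay, at which 4 of the 4 values shown sit.

The compounds shown leave open how far past that limit each of the four lies in this assay, and so whether methyl in place of hydrogen on an oxygen on an aromatic ring changes the result at all.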